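Substituents on the ring nitrogen of the shared core

A few compounds are considered here, and "the series" means these few. Any claim that something is new, unique, unknown or untested is made for them only; others in the source may bear on it.

Compound 1 `COc1ccc(-c2ccc3c(c2)C(=O)C(=O)N3)cc1`: 6920 nM
Compound 2 `COc1ccc(-c2ccc3c(c2)C(=O)C(=O)N3c2ccc(OC)cc2)cc1`: > 10000 nM

In a functional assay on K562 cells (Homo sapiens) for antiproliferative activity, read by MTT assay, with a stated time of 48 h (a higher number here means a weaker inhibitor, a lower number a stronger inhibitor), compound 1 gives 6920 nM. For compound 2 only a limit is reported, > 10000 nM, matching (the limit of > 10000 nM in this assay, at which 1 of the 2 values shown sits). The step of an at least 1.4-fold higher number from compound 1 to compound 2 (0.15 log units; that floor lies within the scatter) is therefore a floor, not a measured size. Compound 3 `COc1ccc(-c2ccc3c(c2)C(=O)C(=O)N3Cc2ccc(Cl)cc2)cc1` carries the change (4-chlorobenzyl in place of 4-methoxyphenyl on an amide-type nitrogen in a ring). Among the compounds with values here, no measured step exchanges one substituent on this nitrogen for another, so the single step available says only that compound 2 already sits at the limit; no direction beyond the scatter is expected in this assay. Compound 3 is estimated at 9000 nM, range 3000 nM to 30000 nM. The expected step of an at least 1.1-fold lower number from compound 2 to compound 3 (0.04 log units; that floor lies within the scatter) is within the scatter, with a limit again likely.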

Compound 3, half-maximal inhibitory concentration: 350 nM
For compound 3 the middle estimate is 26-fold (1.41 log units) above the measured one; the measured number lies below the stated range.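

On the amide-type nitrogen in a ring, a substituent can strengthen activity in this assay, which the step to compound 2 could not show: the step is a 20-fold lower number from compound 1 to compound 3 (1.30 log units; beyond the scatter), with 4-chlorobenzyl replacing hydrogen. Exchanging one substituent for another also matters, and an at least 28-fold lower number from compound 2 to compound 3 (1.45 log units; beyond the scatter) gives only a floor for that step. Compound 2 stands at a limit of the assay: the limit of > 10000 nM in this assay, at which 1 of the 3 values shown sits.

Still open, on these data alone, is whether the gain comes from the chlorine or from the benzyl group itself. Unsubstituted benzyl and 4-methoxybenzyl on this nitrogen would separate the two.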